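The source may hold more compounds than are shown below. What is called first, only, known or untested is meant among the compounds shown, and "the series" means these compounds.

- Compound 1 `CCCCCCn1cnc2c(Nc3ccc(Cl)cc3)nc(N[C@H]3CC[C@H](N)CC3)nc21`: 440 nM
- Compound 2 `CCCCn1cnc2c(NCc3cccc(Cl)c3)nc(N[C@H]3CC[C@H](N)CC3)nc21`: 350 nM
- Compound 3 `CCCCn1cnc2c(Nc3cc(OC)cc(OC)c3)nc(N[C@H]3CC[C@H](N)CC3)nc21`: 370 nM

These values all come from a functional assay on EOL1 cells (Homo sapiens) for inhibition, read by fluorescence, with a stated time of 72 h; on this read-out lower numbers stand for stronger inhibition of growth and higher numbers for weaker inhibition of growth. Compound 3, at 370 nM, sits within the scatter of both other compounds. Compound 4 `CCCCn1cnc2c(Nc3ccc(Cl)cc3)nc(N[C@H]3CC[C@H](N)CC3)nc21` carries 4-chlorophenyl in place of 3,5-dimethoxyphenyl on a nitrogen on an aromatic ring. One measured step changes this same place, a 1.1-fold higher number from compound 2 to compound 3 (0.02 log units; within the scatter), and it stays within the scatter. Though with a hexyl chain where compound 4 has butyl, compound 1 already has the 4-chlorophenyl group, and compound 1 gives 440 nM. For the measured compounds named here, no measured step tests this exact swap, so the expectation is uncertain. The expected change is a 1.2-fold lower number from compound 3 to compound 4 (0.06 log units; within the scatter), with no shift beyond the scatter in either direction. The estimate for compound 4 is 320 nM, with an expected range from 120 nM to 800 nM.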

Compound 4, concentration for 50% growth inhibition: 50 nM
Estimate against measurement, compound 4: 6.4-fold (0.81 log units) above; the measured number lies below the stated range.
By their numbers in this assay, from the lowest: compound 4; then compounds 2, 3 and 1 (each within the scatter of the next).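

In this assay, the group on this nitrogen clearly matters, which the earlier step at this place did not show: 4-chlorophenyl gives a 7.4-fold lower number from compound 3 to compound 4 (0.87 log units; beyond the scatter) and a 7.0-fold lower number from compound 2 to compound 4 (0.85 log units; beyond the scatter). The chain matters too, as butyl in place of hexyl, with 4-chlorophenyl kept, gives an 8.8-fold lower number from compound 1 to compound 4 (0.94 log units; beyond the scatter). Nothing measured here explains either change. Still open, on these data alone, is how a pentyl chain on the core, or a 4-bromophenyl group on this nitrogen, would compare with compound 4.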